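The source may report more compounds than this note shows. Statements on the series, on what has been measured and on what is new or still open speak of the compounds shown alone.

Among the measured compounds shown here, compound 2 `CCCCCCCCCCCCCCCCCCNC(=O)[C@H]1CSC(c2ccc(C#N)cc2)N1` stands at the highest of the two numbers so far in a functional assay on LNCaP cells (Prostate gland, Homo sapiens) for antiproliferative activity, read by sulforhodamine B assay; on this read-out higher numbers stand for weaker inhibition and lower numbers for stronger inhibition: compound 2 gives 5900 nM, whereas compound 1 `CCCCCCCCCCCCCCCCCCNC(=O)[C@H]1CSC(c2c[nH]c3ccccc23)N1` gives 2100 nM, the single recorded step being a 2.8-fold higher number from compound 1 to compound 2 (0.45 log units; beyond the scatter). Compound 3 `CCCCCCCCCCCCCCCCCCNC(=O)[C@H]1CSC(c2cc(F)cc(F)c2)N1` differs from compound 2 by 3,5-difluorophenyl in place of 4-cyanophenyl on a saturated ring carbon. For the measured compounds named here, only that one step bears on the new change, and it concerns a different aryl group, so it offers no direction, only a sign that such swaps on this carbon can move the number beyond the scatter. Compound 3 is therefore expected to change little, a 1.2-fold lower number from compound 2 to compound 3 (0.07 log units; within the scatter). The estimate for compound 3 in this assay is 5000 nM, ranging from 1800 nM to 14000 nM.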

Compound 3, half-maximal inhibitory concentration: 11200 nM
For compound 3 the middle estimate is 2.2-fold (0.35 log units) below the measured one, within the range that was stated.
By their numbers in this assay, from the lowest: compound 1; then compounds 2 and 3 (each within the scatter of the next).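

In this assay the swap on this saturated ring carbon gives a 1.9-fold higher number from compound 2 to compound 3 (0.28 log units; within the scatter), so a nitrile at one place and two fluorines at others leave the phenyl compounds without a readable difference. The step to the 1H-indol-3-yl group widens to a 5.3-fold higher number from compound 1 to compound 3 (0.73 log units; beyond the scatter), and compound 1 now stands apart from both phenyl compounds. No supporting measurement bears on why these numbers fall as they do.

The compounds shown leave open whether a plain phenyl, a 4-methoxyphenyl or a 1H-indol-2-yl group would match compound 1 or compounds 2 and 3.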